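Five-lipoxygenase series: N-aryl succinimides with a 2-oxocyclohexyl group

The compounds below may be only part of what the source reports. "The series", "measured", "known", "first", "only" and "open" are said of these compounds alone.

Measured so far:
compound 1 `O=C1CCCCC1C1CC(=O)N(c2ccccc2)C1=O` — 78300 nM
compound 2 `O=C1CCCCC1C1CC(=O)N(Cc2ccccc2)C1=O` — 36000 nM

In an assay on cells (1-87 tumor cell line) for inhibition of Polyunsaturated fatty acid 5-lipoxygenase (Homo sapiens), with a stated time of 5 min (on this read-out lower numbers stand for stronger inhibition and higher numbers for weaker inhibition), compound 2 gives the lowest of the two numbers; its nearest neighbour is compound 1, and the step of a 2.2-fold lower number from compound 1 to compound 2 (0.34 log units; beyond the scatter) lies beyond the scatter, so benzyl in place of phenyl on the ring nitrogen is a modest gain.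

Compound 3 `O=C1CCCCC1C1CC(=O)N(c2ccc(Br)cc2)C1=O` is not yet measured. It differs from compound 2 by 4-bromophenyl in place of benzyl on an amide-type nitrogen in a ring. For the measured compounds named here, the only step that bears on this change is a 2.2-fold lower number from compound 1 to compound 2 (0.34 log units; beyond the scatter), which runs in the opposite sense: removing the benzyl and returning to a phenyl-type group would undo that gain. Going by the values given here, no measured pair speaks to the bromine. The expectation for compound 3 is therefore a number higher than that of compound 2, of about the size seen before, with a step of a 1.7-fold higher number from compound 2 to compound 3 (0.22 log units; within the scatter). Compound 3 is estimated at 60000 nM, with a range from 25000 nM to 150000 nM.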

Compound 3, half-maximal inhibitory concentration: 131000 nM
Compound 3: the middle estimate sits 2.2-fold (0.34 log units) below what was measured; the measured number falls inside the stated range.
By their numbers in this assay, from the lowest: compound 2; then compounds 1 and 3 (each within the scatter of the next).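

In this assay, 4-bromophenyl in place of benzyl on the amide-type nitrogen in the ring gives a 3.6-fold higher number from compound 2 to compound 3 (0.56 log units; beyond the scatter), so compound 2 keeps the lowest number of the three and the benzyl group stands apart from both aryl groups at this position. Bromo in place of hydrogen on the aromatic carbon gives a 1.7-fold higher number from compound 1 to compound 3 (0.22 log units; within the scatter), so the bromine opens no readable difference on the phenyl ring and compound 1 and compound 3 stand level. Nothing at hand bears on why the numbers fall this way.

Open, on these data alone, is whether 4-bromobenzyl or a longer chain such as 2-phenylethyl on the ring nitrogen would hold or extend the benzyl gain. As far as these compounds go, the 2-oxocyclohexyl group is common to all three compounds, so the effect of a hydroxyl in place of its carbonyl also remains open.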